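Chloro replacing (4-methoxyphenyl)(methyl)amino: cytotoxicity notes

A few compounds are considered here, and "the series" means these few. Any claim that something is new, unique, unknown or untested is made for them only; others in the source may bear on it.

Compound 3 `COc1ccc(N(C)c2nc(Cl)nc3c2ncn3Cc2cc(OC)cc(OC)c2)cc1` carries the shared core with a 3,5-dimethoxybenzyl group and has no number yet in an ADME assay on HT-22 cells (Mus musculus) for cytotoxicity, read by MTT assay, with a stated time of 48 h; a lower number here means that less compound is tolerated, a higher number that more compound is tolerated; its entry there reads "not determined" (no result reported). The same is true of compound 2 `COc1ccc(N(C)c2nc(Cl)nc3c2ncn3Cc2ccc(OC)c(OC)c2)cc1`, which in this assay is recorded as "not determined" (no result reported). Within the data shown here, the only compound of the series with a result is compound 1 `COc1ccc(N(C)c2nc(Cl)nc3c2ncn3C)cc1`, and that result is a limit of the assay rather than a number. In this assay compound 1 gives > 100000 nM. So compound 3 stands beside one limit and one blank, with nothing to rank it against.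

The move to compound 4 `COc1cc(Cn2cnc3c(Cl)nc(Cl)nc32)cc(OC)c1` changes one place on the core: chloro in place of (4-methoxyphenyl)(methyl)amino on an aromatic carbon. Among the measured compounds shown here, no measured pair mirrors this change, so the size of the step in this assay cannot be read from data; the expectation is a step no larger than the scatter, with the result likely to sit near the top of the range again, given that compound 1 already sits at the limit of > 100000 nM in this assay, at which 1 of the 3 values shown sits. For compound 4 the half-maximal cytotoxic concentration in this assay is estimated at 70000 nM, within 15000 nM to 300000 nM.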

Compound 4, half-maximal cytotoxic concentration: > 100000 nM
Compound 4 gave a limit, no number; the forecaster's own chance of this, stated with the estimate: 50%; middle value at least 1.4-fold (0.15 log units) from the limit.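

Among these compounds, compound 3 has no number in this assay, so no step to compound 4 can be read; compound 4 gives a limit, > 100000 nM. The compounds shown leave open what chloro in place of (4-methoxyphenyl)(methyl)amino does to the result in this assay, with the only results so far being limits: the limit of > 100000 nM in this assay, at which 2 of the 4 values shown sit.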